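From compound 2 to compound 4: methoxy for methyl

The source may hold more compounds than are shown below. What is called first, only, known or untested is meant among the compounds shown, and "the series" means these compounds.

Measured in a functional assay on HepG2 cells (Homo sapiens) for antiproliferative activity, read by MTT assay, with a stated time of 72 h (a higher number here means a weaker inhibitor, a lower number a stronger inhibitor), so far
compound 1 `O=C(O)c1csc2nc(CN3CCCCC3)c(-c3ccc(Br)cc3)n12` gives > 100000 nM (a limit)
compound 2 `CCC(=O)NNC(=O)c1csc2ncc(-c3ccc(C)cc3)n12` gives 7340 nM
compound 3 `CCCC(=O)NNC(=O)c1csc2ncc(-c3ccc(C)cc3)n12` gives 26800 nM

Compound 2 holds the lower of the two true numbers, and the entry for compound 1 is only a limit. Compound 4 `CCC(=O)NNC(=O)c1csc2ncc(-c3ccc(OC)cc3)n12` differs from compound 2 as follows: methoxy in place of methyl on an aromatic carbon, a change from 4-methylphenyl to 4-methoxyphenyl. Among the measured compounds shown here, the only measured step of a 3.7-fold higher number from compound 2 to compound 3 (0.56 log units; beyond the scatter) lies on the saturated chain rather than on this aromatic carbon, so it offers only a rough scale. The expected outcome in this assay is a 1.1-fold higher number from compound 2 to compound 4 (0.04 log units; within the scatter) with no step beyond the scatter and no firm direction. Compound 4 is estimated at 8000 nM with an expected range of 2800 nM to 24000 nM in this assay.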

Compound 4, half-maximal inhibitory concentration: 45800 nM
Compound 4: middle estimate off by 5.7-fold (0.76 log units), on the low side; the whole stated range lies below it.
By their numbers in this assay, from the lowest: compound 2; then compounds 3 and 4 (each within the scatter of the next). At a limit, above all of these: compound 1.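

In this assay, the aromatic carbon para to a large group proves sensitive: methoxy in place of methyl gives a 6.2-fold higher number from compound 2 to compound 4 (0.80 log units; beyond the scatter) at this position. With a 3.7-fold higher number from compound 2 to compound 3 (0.56 log units; beyond the scatter) on the saturated chain, both single changes shown from compound 2 raise the number, and neither lowers it. Compound 1 is the only entry at a limit, while compound 4 still reads as a true number: the limit of > 100000 nM in this assay, at which 1 of the 4 values shown sits.

Open, going by these compounds, is whether chloro, hydroxyl or an amine on this aromatic carbon would match compound 2 or go lower.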